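The source may report more compounds than this note shows. Statements on the series, on what has been measured and on what is new or still open speak of the compounds shown alone.

Measured so far:
- Compound 2, `COc1ccc(CCCCCCCCOc2ccc(C[S+]([O-])c3cccc(N)c3)nc2/C=C/C(=O)O)cc1`: 4.7 nM in an assay for binding affinity to leukotriene B4 receptor 1 (Homo sapiens); on this read-out higher numbers stand for weaker inhibition and lower numbers for stronger inhibition
- Compound 1, `COc1ccc(CCCCCCCCOc2ccc(C[S+]([O-])c3cccc(C(=O)O)c3)nc2/C=C/C(=O)O)cc1`: 151 nM in this assay

Going by the values given here, compound 2 gives the lowest of the two numbers; the only other value belongs to compound 1, and the step of a 32-fold lower number from compound 1 to compound 2 (1.51 log units; beyond the scatter) is beyond the scatter. Compound 3, `COc1ccc(CCCCCCCCOc2ccc(C[S+]([O-])c3cccc(N(C)C)c3)nc2/C=C/C(=O)O)cc1`, has not been measured. It differs from compound 2 by dimethylamino in place of amino on an aromatic carbon. Among the compounds with values here, no measured step shows this exchange; the single measured step replaced carboxy by amino, a different change, so it offers only weak guidance. The change keeps the acceptor and removes a donor, so a step of about a 1.2-fold higher number from compound 2 to compound 3 (0.07 log units; within the scatter) is expected, within the usual scatter. For compound 3 a value of 5.5 nM is estimated, between 1.5 nM and 20 nM.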

Compound 3, inhibition constant: 245 nM
Compound 3: middle estimate off by 45-fold (1.65 log units), on the low side; measured number outside the range, above it.
By their numbers in this assay, from the lowest: compound 2; then compounds 1 and 3 (each within the scatter of the next).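

In this assay, dimethylamino in place of amino gives a 52-fold higher number from compound 2 to compound 3 (1.72 log units; beyond the scatter), so this position responds strongly to a change made only on the nitrogen, even though the hydrogen-bond acceptor count stays the same. Dimethylamino in place of carboxy gives a 1.6-fold higher number from compound 1 to compound 3 (0.21 log units; within the scatter), so among these three compounds only the amino group of compound 2 stands apart. Nothing available explains this large step. The compounds shown leave open how methylamino or hydroxy at this position would compare with amino, and so whether the lost hydrogen-bond donor or the added methyl groups matter more.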